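This account rests on a few compounds, and the source may have more. Where it says the series, first, only, none or still open, it means among the compounds named here.

Compound 1 `CCOC(=O)c1cccc(Nc2nccc(-c3ccccn3)n2)c1`: 3000 nM; compound 2 `CCOC(=O)c1cccc(Nc2nccc(-c3cccnc3)n2)c1`: 10500 nM.

In a functional assay for inhibition, with Homo sapiens as the target (on this read-out lower numbers stand for stronger inhibition and higher numbers for weaker inhibition), compound 1 holds the lowest of the two numbers recorded; its nearest neighbour, compound 2, differs from it by a 3.5-fold higher number from compound 1 to compound 2 (0.54 log units; beyond the scatter). Compound 3 `c1ccc(-c2ccnc(Nc3cccc(OCCn4ccnc4)c3)n2)nc1` arises from compound 1 by a change elsewhere: 2-(1H-imidazol-1-yl)ethoxy in place of ethoxycarbonyl on an aromatic carbon. Among the compounds with values here, no measured step concerns that position, so the single known step, the pyridyl swap, offers no guidance for it. Compound 3 is therefore expected to move about no change at the digits printed from compound 1 to compound 3 (within the scatter), with wide uncertainty. The estimated value of compound 3 is 3000 nM, ranging from 700 nM to 13000 nM.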

Compound 3, half-maximal inhibitory concentration: 400 nM
Compound 3: middle estimate off by 7.5-fold (0.88 log units), on the high side; measured number below the stated range.
By their numbers in this assay, from the lowest: compound 3; then compound 1; then compound 2.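

In this assay, 2-(1H-imidazol-1-yl)ethoxy in place of ethoxycarbonyl, on an aromatic carbon meta to a large group, gives a 7.5-fold lower number from compound 1 to compound 3 (0.88 log units; beyond the scatter). This position therefore responds to substitution, and ethoxycarbonyl is not needed there to keep the number of compound 1, since a group with more heavy atoms and a five-membered aromatic ring gives a lower one. No evidence explains this step.

Which part of the new group carries the step remains open, as does whether a simple amine or a longer chain ending in imidazole would match it. Also open, on these data alone, is whether pyridin-3-yl would raise the number on this new side chain as it did on the core of compound 1.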